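This account rests on a few compounds, and the source may have more. Where it says the series, first, only, none or still open, it means among the compounds named here.

Working notes on the series in an assay on Sf9 cells for inhibition of mitogen-activated protein kinase kinase kinase 14 variant S549D (Homo sapiens), with a stated time of 30 min, in the presence of a further agent that is not named here; a higher number here means a weaker inhibitor, a lower number a stronger inhibitor.

Compound 1 `CC(=O)NCCCc1ccc2ncn(-c3ccnc(N)n3)c2c1` reaches only a limit in this assay, > 100000 nM, and the limit itself is the only thing known of it there. Compound 2 `C=Cc1cc(C#Cc2ccc3ncn(-c4ccnc(N)n4)c3c2)ccn1` gives 20000 nM in this assay. Within the data shown here, that is the sole true number in the set; the other result sits at the limit (the limit of > 100000 nM in this assay, at which 1 of the 2 values shown sits), so compound 2 stands as the one compound with a measured value, and no ordering against compound 1 beyond that can be drawn. Among the measured compounds shown here, compound 1 and compound 2 differ in several places at once, so no single step between measured compounds is available to calibrate any change.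

Compound 3 `C#Cc1ccnc(C#Cc2ccc3ncn(-c4ccnc(N)n4)c3c2)c1` has not been measured. It differs from compound 2 by 4-ethynylpyridin-2-yl in place of 2-vinylpyridin-4-yl on a triple-bonded carbon. With no measured step of this kind in hand, the expectation is a change no larger than the usual scatter, in no firm direction: the step from compound 2 to compound 3 is estimated as no change at the digits printed from compound 2 to compound 3 (within the scatter). Compound 3 is therefore expected to give about 20000 nM in this assay, with a range of 5000 nM to 80000 nM, and a real chance that this assay returns only a limit for it.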

Compound 3, half-maximal inhibitory concentration: 316 nM
Estimate against measurement, compound 3: 63-fold (1.80 log units) above; the measured number lies below the stated range.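

In this assay, among these compounds, the place on the triple-bonded carbon proves sensitive to the group it carries: the step of a 63-fold lower number from compound 2 to compound 3 (1.80 log units; beyond the scatter) is the first measured change at this place, and it lies beyond the scatter. The group counts computed for 2-vinylpyridin-4-yl and 4-ethynylpyridin-2-yl match for heavy atoms, hetero atoms, hydrogen-bond donors and hydrogen-bond acceptors, so a large step can arise here with those counts unchanged, while the double bond outside the ring gives way to a triple bond. Nothing measured here bears on the cause of this step.

The names show that the swap alters both the point at which the pyridine is attached and the unsaturated group it carries, so the compounds shown cannot divide the step between these two changes; 4-vinylpyridin-2-yl or 2-ethynylpyridin-4-yl would separate them. Also open, on these data alone, is how far the value of compound 3, 316 nM, holds when the ethynyl group gives way to an amine, a carboxylic acid or a longer chain.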